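The compounds below may be only part of what the source reports. "The series", "measured", "known", "first", "only" and "open" are said of these compounds alone.

In a functional assay (Homo sapiens) for inhibition, with a stated time of 72 h (on this read-out lower numbers stand for stronger inhibition and higher numbers for weaker inhibition), compound 3 `CCn1ccc2cc(C(=O)c3cc(OC)c(OC)c(OC)c3)ccc21` gives 40 nM, the lowest of the two numbers in the series. Compound 2 `COc1cc(C(=O)c2cccc3cc[nH]c23)cc(OC)c1OC` gives 284 nM, a gap from compound 3 that lies beyond the usual scatter. Compound 1 `COc1cc(C(=O)n2ccc3ccccc32)cc(OC)c1OC` reads > 10000 nM, which is a limit of the assay and not a number. Compound 4 `COc1cc(C(=O)c2ccc3c(ccn3CCC(=O)O)c2)cc(OC)c1OC` has carboxy in place of hydrogen on a saturated chain carbon, two bonds along the chain from an aromatic nitrogen, which turns ethyl into 2-carboxyethyl: carboxy in place of hydrogen on a saturated chain carbon, two bonds along the chain from an aromatic nitrogen. Among the measured compounds shown here, no measured pair isolates this change, so the expectation in this assay is a clear move toward weaker inhibition, beyond the scatter. The expected size is a 38-fold higher number from compound 3 to compound 4 (1.57 log units; beyond the scatter). For compound 4 the estimate is 1500 nM, with an expected range of 200 nM to 10000 nM.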

Compound 4, half-maximal inhibitory concentration: > 10000 nM
Compound 4 was reported as a limit (the forecaster's own chance of this, stated with the estimate: 20%); middle value at least 6.6-fold (0.82 log units) from the limit.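

In this assay, among the compounds shown here, the first single-place step is an at least 250-fold higher number from compound 3 to compound 4 (2.39 log units; beyond the scatter): at this position, going from ethyl to 2-carboxyethyl costs much of the inhibition. Compound 4 reads > 10000 nM, which is a limit and not a number, and the step therefore gives only a minimum size: the limit of > 10000 nM in this assay, at which 2 of the 4 values shown sit.

Only ethyl and 2-carboxyethyl are shown at this position, and whether the loss follows the carboxy group or the longer chain stays open. A propyl chain, a 2-hydroxyethyl group or a 2-aminoethyl group in the same place would separate the two.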